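Taking the bromo off compound 2

A few compounds are considered here, and "the series" means these few. Any claim that something is new, unique, unknown or untested is made for them only; others in the source may bear on it.

Compound 1 (`Cc1ccc(NCc2cn(-c3ccccc3)nc2-c2ccc(C)cc2)cc1`) gives > 100000 nM in an ADME assay on BHK-21 cells (Mesocricetus auratus) for cytotoxicity, read by MTT assay, with a stated time of 72 h (on this read-out higher numbers stand for lower toxicity in this test and lower numbers for higher toxicity in this test), as a limit of the assay, not a number. As far as these compounds go, compound 2 (`Cc1ccc(-c2nn(-c3ccccc3)cc2CNc2ccc(Br)cc2)cc1`) gives > 100000 nM in this assay and that is also only a limit, so its true position is unknown. Going by the values given here, the one measured step, a step that the two limits leave unreadable from compound 1 to compound 2 in size, put bromo in place of methyl on an aromatic carbon. Compound 3 (`Cc1ccc(-c2nn(-c3ccccc3)cc2CNc2ccccc2)cc1`), not yet measured, carries hydrogen in place of bromo on an aromatic carbon, para to a large group (hydrogen in place of bromo on an aromatic carbon) in the comparison with compound 2. Among the compounds with values here, the only guide is the limit of > 100000 nM in this assay, at which 2 of the 2 values shown sit, and it shows that neither methyl nor bromo gave a readable number. No shift beyond the usual scatter is therefore expected, in either direction. The estimated change is a number no higher from compound 2 to compound 3 (the limit leaves the size open) and it rests on limits alone. For compound 3 the expected value is 100000 nM with an estimated range from 50000 nM to 200000 nM and another limit is the likeliest report.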

Compound 3, half-maximal cytotoxic concentration: > 100000 nM
Compound 3: a limit, no number; the forecaster's own chance of this, stated with the estimate: 85%; the middle value lies on the limit itself.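

Going by these compounds alone, compound 1, compound 2 and compound 3 all give a limit of the assay rather than a number, so no step among them can be read: the limit of > 100000 nM in this assay, at which 3 of the 3 values shown sit. The compounds shown leave open whether methyl, bromo or hydrogen at this place makes any difference in this assay.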